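A few compounds are considered here, and "the series" means these few. Any claim that something is new, unique, unknown or untested is made for them only; others in the source may bear on it.

Measured so far:
- Compound 1, `CNC(=O)c1cc(Oc2cccc(NC(=S)Nc3ccc(Cl)cc3Cl)c2)ccn1`: 37800 nM in a functional assay on PC-3 cells (Homo sapiens) for cytotoxicity, read by MTT assay, with a stated time of 48 h; a higher number here means a weaker inhibitor, a lower number a stronger inhibitor
- Compound 2, `O=C(NCc1ccccc1)c1cc(Oc2cccc(NC(=S)Nc3ccc(Cl)cc3)c2)ccn1`: 15800 nM
- Compound 3, `CNC(=O)c1cc(Oc2cccc(NC(=S)Nc3ccc(F)c(F)c3)c2)ccn1`: 33100 nM

Compound 3 stands second highest of the three numbers, with compound 1 closest to it and compound 2 furthest; the step of a 1.1-fold lower number from compound 1 to compound 3 (0.06 log units; within the scatter) lies within the scatter, so compounds 1 and 3 are indistinguishable here. Compound 2 differs from compound 3 in two places at once, so its lower number cannot be assigned to either change.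

Compound 4, `O=C(c1cc(Oc2cccc(NC(=S)Nc3ccc(F)c(F)c3)c2)ccn1)N1CCCC1`, is not yet measured. Relative to compound 3 the change is pyrrolidin-1-yl in place of methylamino on a carbonyl carbon. Among the measured compounds shown here, none of the measured steps bears directly on this position: the single measured step alters the arylthiourea end, not the carbonyl substituent. Compound 2 carries a larger group on the amide-type nitrogen than compound 3 and shows a lower number, but with its second difference this gives no clean reading. The step of a 1.1-fold lower number from compound 3 to compound 4 (0.04 log units; within the scatter) is therefore expected to stay within the scatter, in no settled direction. Compound 4 is estimated at 30000 nM, with a range from 12000 nM to 80000 nM.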

Compound 4, half-maximal inhibitory concentration: 45600 nM
Compound 4: the middle estimate sits 1.5-fold (0.18 log units) below what was measured; measured number inside the range.
By their numbers in this assay, from the lowest: compound 2; then compounds 3, 1 and 4 (each within the scatter of the next).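

Among the compounds shown here, at the carbonyl carbon, pyrrolidin-1-yl in place of methylamino gives, in this assay, a 1.4-fold higher number from compound 3 to compound 4 (0.14 log units; within the scatter) as the first reading at this position. The amide hydrogen is absent from compound 4 and the substituent there is larger and cyclic, yet this read-out does not separate compound 4 from compound 3, so on this one pair neither the amide hydrogen nor the added ring registers beyond the scatter. No measurement at hand explains this outcome or links it to any property of either group.

As far as these compounds go, whether a morpholin-4-yl group, a piperidin-1-yl group or a carboxylic acid at this carbon would shift the number beyond the scatter remains open. Also open, from the compounds shown here alone, is whether the benzylamino group of compound 2 matters by itself, since that compound differs from compound 3 in two places.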